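Fluoro for Methyl on the Phenyl Ring: an Expectation

A few compounds are considered here, and "the series" means these few. Any claim that something is new, unique, unknown or untested is made for them only; others in the source may bear on it.

Going by the values given here, compound 2 `Cc1ccc(C(C)NC(=O)/N=C(\N)NCCCc2sc(N)nc2C)cc1` is one of two compounds measured so far in an assay on membranes from Sf9 cells for displacement of a labelled ligand from histamine H2 receptor (Homo sapiens), read by scintillation counting, with a stated time of 60 min (on this read-out higher numbers stand for weaker inhibition and lower numbers for stronger inhibition), where compound 2 gives 30.9 nM. The other, compound 1 `Cc1nc(N)sc1CCCN/C(N)=N/C(=O)NC(C)c1ccc(Br)cc1`, gives 30.2 nM in this assay; the two numbers lie within the scatter of each other, so neither can be called stronger. Among the compounds with values here, the only measured step at this position, a 1.0-fold higher number from compound 1 to compound 2 (0.01 log units; within the scatter), exchanged one group for another on the same aromatic carbon without moving the number beyond the scatter. Compound 3 `Cc1nc(N)sc1CCCN/C(N)=N/C(=O)NC(C)c1ccc(F)cc1` differs from compound 2 by fluoro in place of methyl on an aromatic carbon. Within the data shown here, since the one comparable exchange, a 1.0-fold higher number from compound 1 to compound 2 (0.01 log units; within the scatter), left the number essentially unchanged, the expected step for compound 3 is also within the scatter: a 1.1-fold higher number from compound 2 to compound 3 (0.05 log units; within the scatter). Compound 3 is therefore expected to give about 35 nM in this assay, with a range from 14 nM to 90 nM.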

Compound 3, inhibition constant: 31.6 nM
Estimate against measurement, compound 3: 1.1-fold (0.04 log units) above; measured number inside the range.
By their numbers in this assay, from the lowest: compounds 1, 2 and 3 (each within the scatter of the next).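

In this assay the same aromatic carbon now gives two further readings: fluoro in place of methyl is a 1.0-fold higher number from compound 2 to compound 3 (0.01 log units; within the scatter) and fluoro in place of bromo is a 1.0-fold higher number from compound 1 to compound 3 (0.02 log units; within the scatter) and both steps stay within the scatter. The earlier compounds shown here compared only methyl and bromo, whereas these three compounds show that methyl, bromo and fluoro cannot be told apart here, so the result at this position does not separate a carbon group from either halogen. No measurement shown gives a reason for this match.

From the compounds shown here alone, it remains open whether the same holds for a different kind of group on this carbon, such as an amine, a carboxylic acid or a methoxy group. The compounds also leave open whether hydrogen at this carbon would read the same.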